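Carbamoylpiperidine Replaces the Methanesulfonamide Chain in Compound 3

A few compounds are considered here, and "the series" means these few. Any claim that something is new, unique, unknown or untested is made for them only; others in the source may bear on it.

Of the compounds shown here, two sharing one core have been measured in an assay on HEK293 cells for displacement of a labelled ligand from NPC1-like intracellular cholesterol transporter 1 (Homo sapiens); a higher number here means a weaker inhibitor, a lower number a stronger inhibitor. Compound 1 `CC(C)(C)OC(=O)NCCCCCNC(=O)CN1CN(c2ccccc2)C2(CCN(C(=O)c3ccc(C(C)(C)C)cc3)CC2)C1=O` gives 13700 nM in this assay, while compound 2 `CC(C)(C)c1ccc(C(=O)N2CCC3(CC2)C(=O)N(CC(=O)NCNS(C)(=O)=O)CN3c2ccccc2)cc1` gives 3200 nM. For the measured compounds named here, the single step between them, a 4.3-fold lower number from compound 1 to compound 2 (0.63 log units; beyond the scatter), is the only measured change in this set, and it leaves compound 2 with the lowest of the two numbers.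

Compound 3 `CC(C)(C)c1ccc(C(=O)N2CCC3(CC2)C(=O)N(CC(=O)N2CCCC(C(N)=O)C2)CN3c2ccccc2)cc1` carries a different change at the same end of the molecule: 3-carbamoylpiperidin-1-yl in place of ((methanesulfonamido)methyl)amino on a carbonyl carbon. Going by the values given here, the one measured step touched the saturated chain carbon bound to the amide-type nitrogen, whereas here the whole group on the carbonyl carbon is exchanged, so that step speaks to the tolerance of this region only loosely. Among the compounds with values here, the sole measured step in this region was modest, and there is no step that shows what a ring in place of the open chain does. Compound 3 is therefore expected to sit close to compound 2, with the step of a 1.1-fold higher number from compound 2 to compound 3 (0.04 log units; within the scatter) not clearly beyond the scatter, and its estimated value in this assay is 3500 nM, within a range from 1000 nM to 12000 nM.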

Compound 3, half-maximal inhibitory concentration: 16900 nM
Compound 3: the middle estimate sits 4.8-fold (0.68 log units) below what was measured; measured number above the stated range.
By their numbers in this assay, from the lowest: compound 2; then compounds 1 and 3 (each within the scatter of the next).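

In this assay, the group on this carbonyl carbon turns out not to be freely exchangeable: replacing ((methanesulfonamido)methyl)amino with 3-carbamoylpiperidin-1-yl gives a 5.3-fold higher number from compound 2 to compound 3 (0.72 log units; beyond the scatter) and so leaves compound 2 with the lowest number of the three. This is the first ring shown at this place, and in this single example it does not keep the number of the open chain, with compound 3 now within the scatter of compound 1 even though the two carry different groups at this end of the molecule. No available evidence bears on the origin of this difference.

Since the exchange removes the methanesulfonamido group and introduces both a six-membered ring and a carbamoyl group in one step, the compounds shown do not separate the contribution of the ring from that of its carbamoyl substituent. Plain piperidin-1-yl, 4-carbamoylpiperidin-1-yl or a carboxylic acid in place of the carbamoyl group on the ring would each address part of that question, and whether any ring at this carbonyl carbon can match the open chain remains open.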